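Adding a chloro to compound 1

The source may hold more compounds than are shown below. What is called first, only, known or untested is meant among the compounds shown, and "the series" means these compounds.

In a functional assay on Raji cells (Homo sapiens) for cytotoxicity, with a stated time of 72 h (a higher number here means a weaker inhibitor, a lower number a stronger inhibitor), compound 1 (`CCOC(=O)/C=C/C=C/c1ccc[nH]1`) gives > 10000 nM, which is a limit of the assay and not a number. Its place on the scale is therefore known only as a limit. For the measured compounds named here, the one true number so far belongs to compound 2 (`CCOC(=O)/C=C/C=C/C=C/c1nccs1`), which gives 4350 nM in this assay. Going by the values given here, no single-change comparison between measured compounds is available, so no measured step can serve as a guide here.

Compound 3 (`CCOC(=O)/C=C/C=C/c1[nH]ccc1Cl`) keeps the core of compound 1 and differs from it in one place, with chloro in place of hydrogen on an aromatic carbon. With so little to lean on, the expectation is cautious. A small move toward stronger inhibition is expected in this assay, and a result no different from compound 1 beyond the usual scatter would be just as unsurprising. The expected step is an at least 1.1-fold lower number from compound 1 to compound 3 (0.04 log units; that floor lies within the scatter). For compound 3, the estimated value is 9000 nM, with an expected range from 3000 nM to 27000 nM.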

Compound 3, half-maximal inhibitory concentration: > 10000 nM
Compound 3 gave a limit, no number (the forecaster's own chance of this, stated with the estimate: 55%); middle value at least 1.1-fold (0.04 log units) away from the limit.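

In this assay compound 3 gives > 10000 nM as a limit of the assay and not a number. For the compounds shown here, compound 1 also stands at a limit, and with two limits no step between compound 1 and compound 3 can be read. The compounds shown leave open whether chloro in place of hydrogen on an aromatic carbon changes the strength of inhibition at all.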